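Fatty-acid esters of a shared core: a second chain

This account rests on a few compounds, and the source may have more. Where it says the series, first, only, none or still open, it means among the compounds named here.

compound 1 `CCCCCCCCCC(=O)O[C@H]1[C@H](O)[C@H](n2ccc(N)nc2=O)O[C@@H]1CO`: 0.09 ug/mL
compound 2 `CCCCCCCCCCCCCCCC(=O)O[C@H]1[C@H](O)[C@H](n2ccc(N)nc2=O)O[C@@H]1CO`: 0.24 ug/mL

Two esters of the shared core have been measured in a functional assay on HeLa cells (Homo sapiens) for cytotoxicity, read by cell counting, with a stated time of 48 h; on this read-out higher numbers stand for an effect only at larger amounts of compound and lower numbers for an effect already at smaller amounts. For the measured compounds named here, compound 1 gives the lowest of the two numbers; the only measured step, a 2.7-fold higher number from compound 1 to compound 2 (0.43 log units; beyond the scatter), is modest and lengthens the chain without touching the core.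

Compound 3 `CCCCCCCCCC(=O)OC[C@H]1O[C@@H](n2ccc(N)nc2=O)[C@@H](O)[C@@H]1OC(=O)CCCCCCCCC` is not yet measured. It differs from compound 1 by nonylcarbonyl in place of hydrogen on an oxygen on a saturated carbon, read one bond further out as hydroxy to (nonylcarbonyl)oxy, so a second chain enters while the first stays. Going by the values given here, no measured step adds a chain at this oxygen; the one step that bears on the change, a 2.7-fold higher number from compound 1 to compound 2 (0.43 log units; beyond the scatter), only lengthens the existing chain and raised the number modestly. A second chain of the same kind is expected to move the number in the same direction, as a 2.8-fold higher number from compound 1 to compound 3 (0.44 log units; beyond the scatter). Compound 3 is therefore estimated at 0.25 ug/mL, with a range of 0.08 ug/mL to 0.8 ug/mL.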

Compound 3, concentration for half-maximal effect: 0.11 ug/mL
The estimate for compound 3 lay 2.3-fold (0.36 log units) above the measured number, within the range that was stated.
By their numbers in this assay, from the lowest: compounds 1 and 3 (each within the scatter of the next); then compound 2.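

In this assay, the change from hydroxy to (nonylcarbonyl)oxy on an oxygen on a saturated carbon gives a 1.2-fold higher number from compound 1 to compound 3 (0.09 log units; within the scatter), so this oxygen carries a second chain while the first stays, with no change beyond the scatter. For the compounds shown here, this is the first reading at this oxygen: the earlier step only lengthened the existing chain and moved the number beyond the scatter, whereas the added nonylcarbonyl does not. Nothing at hand explains this outcome.

The compounds shown leave open whether nonylcarbonyl on this oxygen would give a similar number without the first chain. Also open, going by these compounds, is whether a longer chain here, or a chain ending in an amine or a carboxylic acid, would stay within the scatter of compound 1.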